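This account rests on a few compounds, and the source may have more. Where it says the series, first, only, none or still open, it means among the compounds named here.

Measured compounds:
compound 1 `CN1CCN(C(=O)CCCOc2cc(C(=O)N3CCCCc4sccc43)ccc2NC(=O)c2ccccc2-c2ccccc2)CC1` gives 6 nM in an assay on CHO cells for inhibition of Vasopressin V2 receptor (Homo sapiens), read by radioligand binding; on this read-out higher numbers stand for weaker inhibition and lower numbers for stronger inhibition
compound 2 `CN(C)CCN1CCCN(C(=O)c2ccc(NC(=O)c3ccccc3-c3ccccc3)cc2)c2ccsc21` gives 80 nM in this assay

Of the two numbers in this assay compound 1 has the lower one; compound 2 stands at a higher number, and the gap between them lies beyond the scatter. Among the compounds with values here, no step between two measured compounds that differ in one place is available, so the change toward compound 3 `CN1CCCN(C(=O)CCCOc2cc(C(=O)N3CCCCc4sccc43)ccc2NC(=O)c2ccccc2-c2ccccc2)CC1` has no direct precedent here. Compound 3 differs from compound 1 in one place: 4-methyl-1,4-diazepan-1-yl in place of 4-methylpiperazin-1-yl on a carbonyl carbon. The change widens a ring by one member on the chain far from the shared core while keeping the same count of donors and acceptors and the same charge. Such a change is expected to move the number little, if at all beyond the scatter. The step of a 1.3-fold higher number from compound 1 to compound 3 (0.12 log units; within the scatter) is the estimate for compound 3, in either direction within the scatter. For compound 3 the expected value in this assay is 8 nM, with a range from 3 nM to 25 nM.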

Compound 3, half-maximal inhibitory concentration: 10 nM
Estimate against measurement, compound 3: 1.3-fold (0.10 log units) below; low and high end bracket the measured number.
By their numbers in this assay, from the lowest: compounds 1 and 3 (each within the scatter of the next); then compound 2.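

In this assay, 4-methyl-1,4-diazepan-1-yl in place of 4-methylpiperazin-1-yl on a carbonyl carbon gives a 1.7-fold higher number from compound 1 to compound 3 (0.22 log units; within the scatter), so the two compounds cannot be told apart on this read-out. In this one pair, the position takes a seven-membered non-aromatic ring as well as a six-membered one, with one more heavy atom and the same hydrogen-bond donor and acceptor counts and no net charge on either group. Nothing measured here bears on why the two groups read alike.

From the compounds shown here alone, it remains open whether the second ring nitrogen and its methyl matter at this position, as a morpholin-4-yl or an open-chain diethylamino group on the same carbonyl carbon would test. Also open, going by these compounds, is how a longer saturated chain on that carbonyl carbon would read.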